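The compounds below may be only part of what the source reports. "The series", "measured", "known", "first", "only" and "open" are said of these compounds alone.

Measured compounds in an assay on isolated protein for inhibition of prostaglandin G/H synthase 1 (Mus musculus), tested at 10 ug/mL; a higher number here means more inhibition at the concentration tested (going by the name of the read-out), a lower number less inhibition:
compound 1 `CS(=O)(=O)c1ccc(-c2oc3ccccc3c(=O)c2-c2cc(Cl)cc(Cl)c2)cc1`: < 5%
compound 2 `COc1ccc(-c2c(-c3ccc(S(C)(=O)=O)cc3)oc3ccccc3c2=O)cc1`: < 5%

In this assay compound 1 gives only a limit. Compound 2 likewise reaches only a limit, so compound 2 stands at the floor of this read-out. The step that the two limits leave unreadable from compound 1 to compound 2 is unreadable, because the limit of < 5% in this assay, at which 2 of the 2 values shown sit, puts both values at the same limit. Compound 3 `Cc1ccccc1-c1c(-c2ccc(S(C)(=O)=O)cc2)oc2ccccc2c1=O` differs from compound 2 by 2-methylphenyl in place of 4-methoxyphenyl on an aromatic carbon. For the measured compounds named here, no measured step bears on this change, since the only comparison available cannot be read. Compound 3 is therefore expected to remain near the limit, with a step that the limit leaves unreadable from compound 2 to compound 3 not beyond the scatter. The estimate for compound 3 is 3%, ranging from 0% to 15%.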

Compound 3, a percentage reported as inhibition, at one concentration (the size of the read-out at that concentration, not a potency): < 5%
Compound 3: no number, only a limit; the forecaster's own chance of this, stated with the estimate: 80%; the middle value does not contradict the limit.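

Compound 1, compound 2 and compound 3 give no readable step in this assay, because all three values rest on one limit: the limit of < 5% in this assay, at which 3 of the 3 values shown sit.

The compounds shown leave open whether 3,5-dichlorophenyl, 4-methoxyphenyl and 2-methylphenyl differ at all in this assay.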